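Hydroxy added to the core of compound 1

The compounds below may be only part of what the source reports. "The series", "measured", "known", "first", "only" and "open" are said of these compounds alone.

In a functional assay on MCF7 cells (Homo sapiens) for antiproliferative activity (on this read-out lower numbers stand for stronger inhibition and higher numbers for weaker inhibition), compound 1 (`O=C(Nc1ccc(O)c2c(=O)cc(-c3ccccc3Cl)oc12)c1ccc(Cl)cc1`) gives 4600 nM. This is close to compound 3 (`COc1ccc(C(=O)Nc2ccc(O)c3c(=O)cc(-c4ccccc4Cl)oc23)cc1`) at 3500 nM, while compound 2 (`O=C(Nc1ccc(O)c2c(=O)cc(-c3ccccc3Cl)oc12)c1ccc(Cl)c(Cl)c1`) gives the highest number, 15000 nM.

Compound 4 (`O=C(Nc1c(O)cc(O)c2c(=O)cc(-c3ccccc3Cl)oc12)c1ccc(Cl)cc1`) differs from compound 1 by hydroxy in place of hydrogen on an aromatic carbon, ortho to the ((4-chlorophenyl)carbonyl)amino group and meta to a hydroxy group.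

The measured steps, a 3.3-fold higher number from compound 1 to compound 2 (0.51 log units; beyond the scatter) and a 1.3-fold lower number from compound 1 to compound 3 (0.12 log units; within the scatter), all change the aromatic group on the carbonyl carbon. None touches the ring gaining the hydroxy, so they indicate only typical step size, not direction. In this assay, no clear step beyond the scatter is therefore expected.

The expected step is a 1.2-fold lower number from compound 1 to compound 4 (0.06 log units; within the scatter).

Compound 4 is estimated at 4000 nM, with an expected range of 1300 nM to 12000 nM.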

Compound 4, half-maximal inhibitory concentration: 13000 nM
Compound 4: the middle estimate sits 3.3-fold (0.51 log units) below what was measured; measured number outside the range, above it.
By their numbers in this assay, from the lowest: compounds 3 and 1 (each within the scatter of the next); then compounds 4 and 2 (each within the scatter of the next).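

Among the compounds shown here, on the ring that the earlier steps left unchanged, hydroxy in place of hydrogen, ortho to the ((4-chlorophenyl)carbonyl)amino group and meta to a hydroxy group, gives a 2.8-fold higher number from compound 1 to compound 4 (0.45 log units; beyond the scatter) in this assay. This position is therefore not silent: a single added oxygen weakens inhibition beyond the scatter. No measurement shown accounts for the shift.

Open, on these data alone, is whether any group at this position weakens inhibition or only hydroxy does; methoxy or an amine at the same carbon would separate the two. Also open, as far as these compounds go, is whether the step carries over to the 4-methoxyphenyl amide of compound 3.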